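Methyl Replaces Hydrogen on the Pendant Aromatic Ring

The source may hold more compounds than are shown below. What is called first, only, known or untested is meant among the compounds shown, and "the series" means these compounds.

Compound 1 `C=C(C/C(=C\c1ccc(OC(=O)c2ccccc2)cc1)C(=O)c1ccc(OC)cc1)C(=O)c1ccc(OC)cc1` carries a benzoyloxy group on the pendant aromatic ring of the shared core, while compound 2 `C=C(C/C(=C\c1ccccc1)C(=O)c1ccc(OC)cc1)C(=O)c1ccc(OC)cc1` carries only a hydrogen there. In a functional assay on MCF7 cells (Homo sapiens) for inhibition, read by XTT assay, with a stated time of 48 h (a lower number here means a stronger inhibitor, a higher number a weaker inhibitor), compound 1 gives a limit of the assay, > 100000 nM. In this assay, among the measured compounds shown here, compound 2 gives 27100 nM, the only plain number recorded. The step of an at least 3.6-fold lower number from compound 1 to compound 2 (0.56 log units; beyond the scatter) shows that removing the benzoyloxy group strengthened inhibition; the limit of > 100000 nM in this assay, at which 1 of the 2 values shown sits, leaves its true size open. Compound 3 `C=C(C/C(=C\c1ccc(C)cc1)C(=O)c1ccc(OC)cc1)C(=O)c1ccc(OC)cc1` differs from compound 2 by methyl in place of hydrogen on an aromatic carbon. A methyl is a much smaller change than the benzoyloxy group removed before, so no step beyond the scatter is expected from compound 2 to compound 3, at most a slight gain. The step of a 1.4-fold lower number from compound 2 to compound 3 (0.13 log units; within the scatter) is the expected change. Compound 3 is therefore estimated at 20000 nM, with a likely range from 7000 nM to 60000 nM.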

Compound 3, half-maximal inhibitory concentration: 26900 nM
Beside the measured number, compound 3's estimate is 1.3-fold (0.13 log units) below it; the range from low to high includes it.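

In this assay the step of a 1.0-fold lower number from compound 2 to compound 3 (0.00 log units; within the scatter) shows that going from phenyl to 4-methylphenyl gives no readable difference, so a single methyl at this place on the ring does not separate compound 3 from compound 2. The step of an at least 3.7-fold lower number from compound 1 to compound 3 (0.57 log units; beyond the scatter) shows that methyl, like hydrogen, gives a stronger reading than the benzoyloxy group, so merely having something other than hydrogen at this place does not account for the weak result of compound 1. The true size of that step stays open because compound 1 gives only a limit: the limit of > 100000 nM in this assay, at which 1 of the 3 values shown sits.

The compounds shown leave open whether an amine, a carboxylic acid or a longer chain at this place would move the number beyond the scatter. They also leave open whether a smaller ester such as acetoxy would behave like benzoyloxy.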